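The compounds below may be only part of what the source reports. "The series", "measured", "known", "first", "only" and "open" are said of these compounds alone.

Measured in a functional assay on the whole organism for inhibition, with Cavia porcellus as the target; on this read-out higher numbers stand for an effect only at larger amounts of compound and lower numbers for an effect already at smaller amounts:
- Compound 1 `CN(C)/C(=N\C#N)C1=CC(C)(C)Oc2ccc(C#N)cc21`: 2140 nM
- Compound 2 `CN(C)/C(=N\C#N)C1=CC(C)(C)Oc2ccc(C(F)(F)F)cc21`: 178 nM

Of these two compounds, compound 2 has the lower number, at 178 nM, while compound 1 stands at 2140 nM. Compound 3 `CN(C)/C(=N\C#N)C1=CC(C)(C)Oc2ccccc21` has not yet been measured. It departs from compound 2 by one change: hydrogen in place of trifluoromethyl on an aromatic carbon. In short, hydrogen takes the place of trifluoromethyl on an aromatic carbon.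

Among the measured compounds shown here, only one measured step bears on this change, as it concerns the same aromatic carbon: a 12-fold lower number from compound 1 to compound 2 (1.08 log units; beyond the scatter). That step is large and shows that the number in this assay can respond strongly to the group at this carbon. For the measured compounds named here, no measured compound carries hydrogen there, so the data cannot fix the size of the new step, and a wide range is warranted. Going by the values given here, since compound 2 holds the lowest number so far, a move to a higher number is expected, of about the size seen in a 12-fold lower number from compound 1 to compound 2 (1.08 log units; beyond the scatter). The expected change is a 14-fold higher number from compound 2 to compound 3 (1.15 log units; beyond the scatter). For compound 3 the estimated value is 2500 nM, with an expected range from 600 nM to 10000 nM.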

Compound 3, half-maximal effective concentration: > 31600 nM
Compound 3: no number, only a limit (the forecaster's own chance of this, stated with the estimate: 10%); middle value at least 12-fold (1.10 log units) from the limit.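

For compound 3, the read-out in this assay is a limit and not a number: the limit of > 31600 nM in this assay, at which 1 of the 3 values shown sits.

Even so, the steps can be read in one direction, with an at least 170-fold higher number from compound 2 to compound 3 (2.24 log units; beyond the scatter) for the loss of trifluoromethyl and an at least 14-fold higher number from compound 1 to compound 3 (1.16 log units; beyond the scatter) for the loss of cyano. Among the compounds shown here, the earlier compounds showed only that the two groups differ from each other at this aromatic carbon, whereas these steps show that each of them, cyano as well as trifluoromethyl, gives a lower number than hydrogen does. The group here therefore matters in more than the choice between two substituents: among the three compounds, the one with only hydrogen at this carbon has the highest read-out, and none goes against that order.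

As far as these compounds go, how far compound 3 actually lies from the other two stays unknown, as the true size of both steps is bounded on one side only. From the compounds shown here alone, it also remains open whether a smaller group such as fluorine or chlorine, or a different one such as an amine, a carboxylic acid or a longer chain, would keep the number low at this carbon.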